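The compounds below may be only part of what the source reports. "The series", "measured", "known", "first", "only" and "open" are said of these compounds alone.

Of the compounds shown here, three have been measured in a functional assay on cells (T-cell line, Homo sapiens) for inhibition; on this read-out higher numbers stand for weaker inhibition and lower numbers for stronger inhibition. Compound 1, with the structure `COc1ccc(CCCN2CCC(COCc3ccccn3)CC2)cc1`, gives 5900 nM. Compound 2, with the structure `Clc1ccc(CCCN2CCC(COC(c3ccccc3)c3ccccc3)CC2)cc1`, gives 500 nM, the lowest of the three numbers, which means the strongest inhibition seen so far. Compound 3, with the structure `CCCCCCCCCCN1CCC(COC(c2ccccc2)c2ccccc2)CC1`, gives 2600 nM. Compound 1 differs from compound 2 in two places at once, so its higher number cannot be tied to a single change.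

Going by the values given here, the only single-point step among the measured compounds runs from compound 2 to compound 3: a 5.2-fold higher number from compound 2 to compound 3 (0.72 log units; beyond the scatter). It shows that changing the group attached to the chain on the ring amine nitrogen moves the number by a modest amount, but does not wipe out inhibition.

Compound 4, with the structure `c1ccc(C(OCC2CCN(CC3CCc4ccccc4C3)CC2)c2ccccc2)cc1`, has not been measured. It differs from compound 2 as follows: 1,2,3,4-tetrahydronaphthalen-2-yl in place of 2-(4-chlorophenyl)ethyl on a saturated chain carbon bound to an amine nitrogen in a ring. This change touches the same chain as the step from compound 2 to compound 3, but keeps one aromatic ring, so a smaller shift toward a higher number, or none beyond the scatter, is expected: a 2.0-fold higher number from compound 2 to compound 4 (0.30 log units; within the scatter). Compound 4 is therefore estimated at 1000 nM, with a likely range from 300 nM to 4000 nM.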

Compound 4, half-maximal inhibitory concentration: 5600 nM
Estimate against measurement, compound 4: 5.6-fold (0.75 log units) below; the measured number lies above the stated range.
By their numbers in this assay, from the lowest: compound 2; then compound 3; then compounds 4 and 1 (each within the scatter of the next).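

In this assay an aromatic ring on this chain does not by itself keep the number low: the 1,2,3,4-tetrahydronaphthalen-2-yl group carries one, yet it gives an 11-fold higher number from compound 2 to compound 4 (1.05 log units; beyond the scatter) and so costs more than the step with no ring in the entering group, a 5.2-fold higher number from compound 2 to compound 3 (0.72 log units; beyond the scatter) at the same part of the molecule. The nonyl group, which has no ring, also does better here, with a 2.2-fold higher number from compound 3 to compound 4 (0.33 log units; beyond the scatter) when it is replaced, so among these three groups on a saturated chain carbon bound to an amine nitrogen in a ring, 2-(4-chlorophenyl)ethyl gives the lowest number and 1,2,3,4-tetrahydronaphthalen-2-yl the highest. Nothing available here accounts for the size of these steps.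

The change to compound 4 removes the chlorine and adds a non-aromatic ring in one move. The measured compounds do not separate these two changes, and a plain 2-phenylethyl group at this place would do so. Also open, from the compounds shown here alone, is whether a 2-(4-fluorophenyl)ethyl group could match or improve on the 2-(4-chlorophenyl)ethyl group of compound 2.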